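Methoxy on the anilino ring of a thiazolyl acetamide

The source may report more compounds than this note shows. Statements on the series, on what has been measured and on what is new or still open speak of the compounds shown alone.

Compound 1 `Cc1nc(SCC(=O)Nc2nc(-c3ccc(Cl)cc3)cs2)n(Nc2ccccc2)c1C` is the stronger of the two measured compounds in a functional assay on HCT-116 cells (Homo sapiens) for antiproliferative activity, read by sulforhodamine B assay, with a stated time of 48 h (a higher number here means a weaker inhibitor of growth, a lower number a stronger inhibitor of growth), where compound 1 gives 4620 nM. Going by the values given here, the only other measured compound, compound 2 `Cc1ccc(Nn2c(SCC(=O)Nc3nc(-c4ccccc4)cs3)nc(C)c2C)cc1`, differs from it in more than one place and gives 26500 nM in this assay, a weaker result that lies beyond the scatter but cannot be tied to any single change. Compound 3 `COc1ccc(Nn2c(SCC(=O)Nc3nc(-c4ccc(Cl)cc4)cs3)nc(C)c2C)cc1` keeps the whole of compound 1 and adds one group: methoxy in place of hydrogen on an aromatic carbon, on an aromatic carbon of a six-membered aromatic ring of carbon only, para to a large group. Among the compounds with values here, no measured pair shows the effect of such a substitution on this scaffold, so nothing beyond the scatter is expected, with a slight lean toward a higher number. The step from compound 1 to compound 3 in this assay is expected to be a 1.3-fold higher number from compound 1 to compound 3 (0.11 log units; within the scatter). Compound 3 is therefore estimated to give 6000 nM in this assay, within a range of 2500 nM to 15000 nM.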

Compound 3, concentration for total growth inhibition: 14100 nM
Beside the measured number, compound 3's estimate is 2.4-fold (0.37 log units) below it; measured number inside the range.
By their numbers in this assay, from the lowest: compound 1; then compounds 3 and 2 (each within the scatter of the next).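

Going by these compounds alone, the new pair gives the first reading of a single change on this scaffold: in this assay, going from anilino to (4-methoxyphenyl)amino brings a 3.1-fold higher number from compound 1 to compound 3 (0.48 log units; beyond the scatter), a modest loss of growth inhibition. This place on the aromatic ring, para to a large group, is therefore not indifferent to substitution, at least for methoxy. Nothing measured here accounts for the step.

The compounds shown leave open whether this loss is particular to methoxy or would follow any group at this place, a question that a fluorine, a methyl or a hydroxyl there could begin to answer. They also leave open whether methoxy elsewhere on the same ring would give a similar step.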